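Methoxy for fluoro on the benzylamine of the core

This account rests on a few compounds, and the source may have more. Where it says the series, first, only, none or still open, it means among the compounds named here.

The series shares one core, as in compound 1 `Nc1cc(N)c2nc(-c3ccccc3)c(NCc3ccc(Cl)c(Cl)c3)nc2c1`, which in a functional assay on OVCAR-3 cells (Homo sapiens) for inhibition, read by sulforhodamine B assay, with a stated time of 48 h (a lower number here means that less compound is tolerated, a higher number that more compound is tolerated), gives 31600 nM. Compound 2 `COc1ccc(CNc2nc3cc(N)cc(N)c3nc2-c2ccccc2)cc1OC` gives 8510 nM in this assay, and the step of a 3.7-fold lower number from compound 1 to compound 2 (0.57 log units; beyond the scatter) is the only readable move among the measured pairs. Compound 3 `Nc1cc(N)c2nc(-c3ccccc3)c(NCc3ccc(F)cc3)nc2c1` is reported in this assay only as a limit, < 100000 nM, so its place on the scale is not fixed; this is recorded as the limit of < 100000 nM in this assay, at which 1 of the 3 values shown sits. For the same reason the steps a step that the limit leaves unreadable from compound 1 to compound 3 and a step that the limit leaves unreadable from compound 2 to compound 3 cannot be sized.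

Compound 4 `COc1ccc(CNc2nc3cc(N)cc(N)c3nc2-c2ccccc2)cc1` differs from compound 3 by methoxy in place of fluoro on an aromatic carbon. Among the compounds with values here, no measured step matches this change directly. The closest guide is the move from compound 1 to compound 2, where methoxy groups in place of chloro atoms brought a modest gain, and compound 2 carries the nearer methoxy pattern to compound 4. Because compound 3 gives only a limit, the step from compound 3 to compound 4 is expected to read as a step that the limit leaves unreadable from compound 3 to compound 4, but its size rests on the limit, not on a number. Compound 4 is expected to give about 15000 nM in this assay, within 4000 nM to 60000 nM.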

Compound 4, concentration lethal to 50% of the cells: 38900 nM
The estimate for compound 4 lay 2.6-fold (0.41 log units) below the measured number, and the stated range covers the measured number.
By their numbers in this assay, from the lowest: compound 2; then compounds 1 and 4 (each within the scatter of the next).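

In this assay, within the data shown here, the single methoxy group of compound 4 does not reproduce what the dimethoxy pattern gives: the loss of one methoxy group, with hydrogen in its place, reads as a 4.6-fold higher number from compound 2 to compound 4 (0.66 log units; beyond the scatter). The lower number of compound 2 therefore depends on the full 3,4-dimethoxyphenyl group, not on the presence of any methoxy group on that ring. Set against the 3,4-dichlorophenyl group, the 4-methoxyphenyl group gives a 1.2-fold higher number from compound 1 to compound 4 (0.09 log units; within the scatter), so compound 1 and compound 4 are not separated here, and compound 3 stands only as a limit, which leaves the step for methoxy in place of fluoro and every other step to compound 3 unreadable: the limit of < 100000 nM in this assay, at which 1 of the 4 values shown sits.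

The compounds shown leave open whether a single methoxy group at the other ring carbon of compound 2 would carry the lower number, and whether the pattern depends on methoxy itself or would also hold for two ethoxy groups or a fused methylenedioxy ring. Also open, on these data alone, is how a hydroxyl, an amine or a carboxylic acid in place of the methoxy group of compound 4 would read, or a longer chain in place of the benzyl carbon.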